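From Ethyl to Methylamino on Compound 2

This account rests on a few compounds, and the source may have more. Where it says the series, first, only, none or still open, it means among the compounds named here.

For the measured compounds named here, in a functional assay (aorta) for inhibition, with Rattus norvegicus as the target, with a stated time of 8 days (on this read-out lower numbers stand for stronger inhibition and higher numbers for weaker inhibition), compound 2 `CCc1nsc(-c2ccc(N3CCN(c4cccc(C(F)(F)F)c4)CC3)nn2)n1` gives 8 nM as the only exact number so far. Compound 1 `Cc1nsc(-c2nccc(N3CCN(c4cccc(C(F)(F)F)c4)CC3)n2)n1` reads > 100 nM in this assay and this is a limit of the assay, not a number. Compound 3 `CNc1nsc(-c2ccc(N3CCN(c4cccc(C(F)(F)F)c4)CC3)nn2)n1` keeps the core of compound 2 but has methylamino in place of ethyl on an aromatic carbon of the five-membered ring. Going by the values given here, no measured step shows what this swap does, so the expectation is cautious. An estimated step of a 2.5-fold higher number from compound 2 to compound 3 (0.40 log units; beyond the scatter) is expected to be moderate, toward weaker inhibition and slightly beyond the usual scatter. Compound 3 is expected at 20 nM (between 5 nM and 80 nM) by this estimate.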

Compound 3, half-maximal inhibitory concentration: 3 nM
Estimate against measurement, compound 3: 6.7-fold (0.82 log units) above; measured number outside the range, below it.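

Methylamino in place of ethyl on an aromatic carbon of the five-membered ring gives a 2.7-fold lower number from compound 2 to compound 3 (0.43 log units; beyond the scatter) in this assay, the first measured step at this position. The two groups have the same count of heavy atoms, yet methylamino brings a hydrogen-bond donor that ethyl lacks, and inhibition does not weaken with this change. Nothing measured here explains why the number falls. From the compounds shown here alone, how a plain amine, a dimethylamino group or a methoxy group would read at this position stays open, and a single step cannot establish a trend.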